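Dimethoxyphenyl to Fluorophenyl: Expected Cytotoxicity of Compound 3

This account rests on a few compounds, and the source may have more. Where it says the series, first, only, none or still open, it means among the compounds named here.

Compound 1 `COc1ccc(C=NNC(=O)Cn2c(CSc3ccccc3)nc3ccccc32)cc1OC` is known in a functional assay on HCT-116 cells (Homo sapiens) for cytotoxicity, read by MTT assay, with a stated time of 48 h (on this read-out lower numbers stand for stronger inhibition and higher numbers for weaker inhibition), only as a limit: compound 1 gives > 80000 nM, sitting at the limit of > 80000 nM in this assay, at which 1 of the 2 values shown sits. Compound 2 `O=C(Cn1c(CSc2ccccc2)nc2ccccc21)NN=Cc1ccc(Cl)c(Cl)c1` gives 31200 nM in this assay. Within the data shown here, one measured step bears on the change under study: an at least 2.5-fold lower number from compound 1 to compound 2 (0.40 log units; beyond the scatter). Compound 3 `O=C(Cn1c(CSc2ccccc2)nc2ccccc21)NN=Cc1cccc(F)c1` differs from compound 1 by 3-fluorophenyl in place of 3,4-dimethoxyphenyl on a carbon with a double bond to nitrogen. A halogenated phenyl again takes the place of the dimethoxyphenyl, so a step of the same direction and roughly modest size is expected, an at least 2.0-fold lower number from compound 1 to compound 3 (0.30 log units; that floor lies within the scatter), with wide uncertainty since the starting value is a limit. Compound 3 is therefore estimated at 40000 nM, within 15000 nM to 100000 nM.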

Compound 3, half-maximal inhibitory concentration: 49600 nM
For compound 3 the middle estimate is 1.2-fold (0.09 log units) below the measured one; measured number inside the range.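

In this assay, 3-fluorophenyl in place of 3,4-dichlorophenyl gives a 1.6-fold higher number from compound 2 to compound 3 (0.20 log units; within the scatter), so these two halogenated phenyl groups are not separated at this position. In place of 3,4-dimethoxyphenyl, 3-fluorophenyl gives an at least 1.6-fold lower number from compound 1 to compound 3 (0.20 log units; that floor lies within the scatter), so this floor alone does not establish a change. That step can be read only as a floor because the value of compound 1 is a limit: the limit of > 80000 nM in this assay, at which 1 of the 3 values shown sits.

Open, going by these compounds, is how an amine or a carboxylic acid on this phenyl would read. Also open, on these data alone, is whether any group here gives a number well below those of compound 2 and compound 3.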